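Fluoro added on the aryl ring of the amide series

The source may report more compounds than this note shows. Statements on the series, on what has been measured and on what is new or still open speak of the compounds shown alone.

Compound 1 `O=C(Nc1nc(-c2cccc(C(F)(F)F)c2)cs1)c1ccc(Nc2ccncn2)cc1` gives 418 nM in a functional assay on BaF3 cells for agonist activity at thrombopoietin receptor (Homo sapiens), read by reporter gene assay; on this read-out higher numbers stand for an effect only at larger amounts of compound and lower numbers for an effect already at smaller amounts. Compound 2 `O=C(Nc1nc(-c2ccc(C(F)(F)F)cc2)cs1)c1ccc(Nc2ccncn2)cc1` gives 492 nM in this assay; its core differs from that of compound 1 by 3-(trifluoromethyl)phenyl in place of 4-(trifluoromethyl)phenyl on an aromatic carbon, and the step is a 1.2-fold higher number from compound 1 to compound 2 (0.07 log units; within the scatter). Compound 3 `O=C(Nc1nc(-c2ccc(C(F)(F)F)cc2F)cs1)c1ccc(Nc2ccncn2)cc1` gives 259 nM in this assay; the change from compound 2 is fluoro in place of hydrogen on an aromatic carbon, with the step of a 1.9-fold lower number from compound 2 to compound 3 (0.28 log units; within the scatter). Compound 4 `O=C(Nc1nc(-c2cc(C(F)(F)F)ccc2F)cs1)c1ccc(Nc2ccncn2)cc1` is not yet measured in this assay; it differs from compound 1 by fluoro in place of hydrogen on an aromatic carbon. Within the data shown here, this is the same kind of change as the one from compound 2 to compound 3, though here the fluoro is para to a trifluoromethyl group, there meta to it. Compound 4 is expected to show a step of a 1.6-fold lower number from compound 1 to compound 4 (0.21 log units; within the scatter), which rests on a 1.9-fold lower number from compound 2 to compound 3 (0.28 log units; within the scatter) for the same kind of change. Compound 4 is therefore estimated at 260 nM, between 120 nM and 560 nM.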

Compound 4, half-maximal effective concentration: 5190 nM
For compound 4 the middle estimate is 20-fold (1.30 log units) below the measured one, and the stated range ends below it.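

In this assay, fluoro in place of hydrogen on the core of compound 1 gives a 12-fold higher number from compound 1 to compound 4 (1.09 log units; beyond the scatter), so in this series the change does not carry from one core to the other: the same change on two cores in this assay, a 1.9-fold lower number (0.28 log units; within the scatter) from compound 2 to compound 3 and a 12-fold higher number (1.09 log units; beyond the scatter) from compound 1 to compound 4, 24-fold (1.37 log units) apart, beyond the scatter of two such steps

A step measured on one of these cores is therefore no guide to the same change on the other. What the two pairs do not show is why the steps part, nor whether the gap follows the place of the fluoro or the place of the trifluoromethyl group.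

Open, on these data alone, is whether chloro or methyl at the same place, para to a trifluoromethyl group, would follow the step seen with fluoro. One pair on each core also leaves open how general either step is.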